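The compounds below may be only part of what the source reports. "The series", "measured", "known", "first", "only" and "open" are said of these compounds alone.

Compounds measured in a functional assay for inhibition of sodium/hydrogen exchanger (Oryctolagus cuniculus); a higher number here means a weaker inhibitor, a lower number a stronger inhibitor:
compound 1, `Cc1cc(Oc2ccccc2)c(S(C)(=O)=O)cc1C(=O)N=C(N)N`, 10 nM
compound 2, `Cc1cc(N)c(S(C)(=O)=O)cc1C(=O)N=C(N)N`, 16 nM
compound 3, `Cc1cc(Nc2ccccc2)c(S(C)(=O)=O)cc1C(=O)N=C(N)N`, 21 nM

Among the three numbers compound 3 sits at the upper end: a 1.3-fold higher number from compound 2 to compound 3 (0.12 log units; within the scatter), within the scatter, and a 2.1-fold higher number from compound 1 to compound 3 (0.32 log units; beyond the scatter), beyond it.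

Compound 4, `Cc1cc(Nc2ncccn2)c(S(C)(=O)=O)cc1C(=O)N=C(N)N`, differs from compound 3 by pyrimidin-2-yl in place of phenyl on a nitrogen on an aromatic ring. Going by the values given here, no measured pair swaps one ring for another on that nitrogen, so the change is not covered directly. The nearest guides are the step of a 1.3-fold higher number from compound 2 to compound 3 (0.12 log units; within the scatter), which shows that placing the phenyl on the nitrogen moved the number little, and the step of a 2.1-fold higher number from compound 1 to compound 3 (0.32 log units; beyond the scatter), which is modest. Both variations at this position have so far shifted the number only slightly, so for compound 4 the expected step of a 1.2-fold higher number from compound 3 to compound 4 (0.08 log units; within the scatter) is none beyond the scatter. Compound 4 is estimated at 25 nM in this assay, range 10 nM to 60 nM.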

Compound 4, half-maximal inhibitory concentration: 8.3 nM
Compound 4: the middle estimate sits 3.0-fold (0.48 log units) above what was measured; the whole stated range lies above it.
By their numbers in this assay, from the lowest: compounds 4, 1, 2 and 3 (each within the scatter of the next, the first and the last beyond it).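

In this assay the identity of the ring on the nitrogen now matters: a 2.5-fold lower number from compound 3 to compound 4 (0.40 log units; beyond the scatter) goes beyond the scatter, while adding phenyl to that nitrogen in the earlier step did not. The other two comparisons give a different reading, with a 1.9-fold lower number from compound 2 to compound 4 (0.29 log units; within the scatter) and a 1.2-fold lower number from compound 1 to compound 4 (0.08 log units; within the scatter) both within the scatter, so the pyrimidin-2-yl compound separates only from the anilino compound. The swap keeps six heavy atoms in a six-membered aromatic ring and brings in two ring nitrogens, which places the difference in ring composition rather than ring size. Nothing at hand explains why this step occurs.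

On these data alone, it remains open whether a single ring nitrogen, as in pyridin-2-yl, would give the same reading. Also open, as far as these compounds go, is how a methyl or an amine on the pyrimidine, or a saturated piperidine on that nitrogen, would behave.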